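This account rests on a few compounds, and the source may have more. Where it says the series, first, only, none or still open, it means among the compounds named here.

Working notes on the series.

Compound 1 `COC[C@H]1OC(OCc2ccc(Cl)cc2)[C@H](NC(=O)CCCN=C(N)N)[C@@H](OCc2ccc(Cl)cc2)[C@@H]1O` is the reference point. Among the compounds with values here, in an assay on CHO cells for displacement of a labelled ligand from melanin-concentrating hormone receptor 1 (Homo sapiens), read by scintillation counting (a higher number here means a weaker inhibitor, a lower number a stronger inhibitor), compound 1 gives 1200 nM, the lowest of the two numbers measured so far. Within the data shown here, the only measured partner is compound 2 `COC[C@H]1OC(OCCc2ccccc2)[C@H](NC(=O)CCCN=C(N)N)[C@@H](OCc2ccc(Cl)cc2)[C@@H]1O`, which in this assay gives 3500 nM; the step of a 2.9-fold higher number from compound 1 to compound 2 (0.46 log units; beyond the scatter) is the one measured change at this position, a swap of the aromatic group on a saturated chain carbon bound to an oxygen on a saturated carbon.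

Compound 3 `COC[C@H]1OC(OCc2ccc(Cl)cc2)[C@H](NC(=O)CCCN=C(N)N)[C@@H](OCc2ccc3ccccc3c2)[C@@H]1O` has not yet been measured. Relative to compound 1 the change is naphthalen-2-yl in place of 4-chlorophenyl on a saturated chain carbon bound to an oxygen on a saturated carbon. The step from compound 1 to compound 2 bears on it only in that it shows the group at this place matters to the result in this assay, and that the smaller benzyl gave the higher number. Nothing measured speaks to a larger aromatic group here. Compound 3 is therefore expected to land near compound 1, with an estimated step of a 1.3-fold lower number from compound 1 to compound 3 (0.12 log units; within the scatter), the direction uncertain. The estimate for compound 3 in this assay is 900 nM, within a range of 300 nM to 3000 nM.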

Compound 3, inhibition constant: 2600 nM
Estimate against measurement, compound 3: 2.9-fold (0.46 log units) below; low and high end bracket the measured number.
By their numbers in this assay, from the lowest: compound 1; then compounds 3 and 2 (each within the scatter of the next).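

In this assay the replacement of 4-chlorophenyl by naphthalen-2-yl gives a 2.2-fold higher number from compound 1 to compound 3 (0.34 log units; beyond the scatter), so the larger aromatic group, with 2 six-membered aromatic rings of carbon only and no chlorine, does not lower the number. Within the data shown here, compound 1 carries two (4-chlorobenzyl)oxy groups, and this is the first measured change at this one, since the change in compound 2 lies on the other; the result therefore shows that this group also matters to the result, and that of the two aromatic groups measured here, 4-chlorophenyl gives the lower number. No measurement available here accounts for the step.

Because the ring size and the chlorine change together in compound 3, the compounds shown do not separate what each contributes to the step. A 4-bromobenzyl or 4-methoxybenzyl group at this place would keep a single six-membered aromatic ring while changing only the chlorine, and a pyridin-3-ylmethyl group would put a ring nitrogen into the same place, so the series leaves both of these changes open.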